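This account rests on a few compounds, and the source may have more. Where it says the series, first, only, none or still open, it means among the compounds named here.

Measured compounds in an assay on membranes from brain for binding affinity to Lysophosphatidylserine lipase ABHD12 (Mus musculus), read by fluorescence, with a stated time of 20 min; on this read-out higher numbers stand for weaker inhibition and lower numbers for stronger inhibition:
- Compound 1 `S=C(Nc1cccnc1)NC1CCN(c2cc(OCc3ccccc3)ccn2)CC1` gives 2800 nM
- Compound 2 `COc1ccc(Oc2ccnc(N3CCC(NC(=S)Nc4cccnc4)CC3)c2)cc1` gives 2900 nM
- Compound 3 `Fc1ccc(Oc2ccnc(N3CCC(NC(=S)Nc4cccnc4)CC3)c2)cc1` gives 1400 nM

All three share one core and differ only in the group hung on an oxygen on an aromatic ring. Among the compounds with values here, compound 3 holds the lowest number of the three in this assay, yet its distance from compound 1 lies within the scatter, so the two cannot be ranked; only the step from compound 2 to compound 3, 2>3 a 2.1-fold lower number from compound 2 to compound 3 (0.32 log units; beyond the scatter), counts as a real, if modest, difference.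

Compound 4 `S=C(Nc1cccnc1)NC1CCN(c2cc(Oc3ccccc3)ccn2)CC1` is not yet measured. It differs from compound 3 by hydrogen in place of fluoro on an aromatic carbon, at a carbon of a six-membered aromatic ring of carbon only, para to a large group: in wider terms, 4-fluorophenoxy becomes phenoxy.

Within the data shown here, the one step that bears on this is a 2.1-fold lower number from compound 2 to compound 3 (0.32 log units; beyond the scatter), which swapped one small group for another at the same position and moved the number modestly. Removing the fluoro altogether is a change of similar scale, and the other steps, a 1.0-fold higher number from compound 1 to compound 2 (0.02 log units; within the scatter) and a 2.0-fold lower number from compound 1 to compound 3 (0.30 log units; within the scatter), show that larger rearrangements of this group barely moved the numbers at all. The expectation for compound 4 is therefore a step of about a 1.4-fold higher number from compound 3 to compound 4 (0.15 log units; within the scatter), most likely within the scatter, perhaps slightly toward a higher number. The estimate for compound 4 in this assay is 2000 nM, with a range from 900 nM to 4500 nM.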

Compound 4, half-maximal inhibitory concentration: 1900 nM
The estimate for compound 4 lay 1.1-fold (0.02 log units) above the measured number, and the stated range covers the measured number.
By their numbers in this assay, from the lowest: compounds 3, 4, 1 and 2 (each within the scatter of the next, the first and the last beyond it).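

Within the data shown here, compound 4 adds what the earlier compounds could not show: how the phenoxy group reads with no substituent on its aromatic ring. In this assay, removing the fluoro gives a 1.4-fold higher number from compound 3 to compound 4 (0.13 log units; within the scatter), so this position does not need the fluoro to keep a number in this range. The unsubstituted group also stays close to the other two groups, with a 1.5-fold lower number from compound 2 to compound 4 (0.18 log units; within the scatter) against methoxy and a 1.5-fold lower number from compound 1 to compound 4 (0.17 log units; within the scatter) against the benzyl group on the oxygen, and this leaves the step between the methoxy and fluoro compounds as the only difference in the set that clears the scatter. No measurement is available that would explain why these numbers lie so close together.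

From the compounds shown here alone, what remains open is whether a group of a different kind at this position, such as an amine, a carboxylic acid or a longer chain like butyl, would move the number clearly beyond the scatter in either direction. Going by these compounds, it is also open whether a chloro or trifluoromethyl group in place of the fluoro would give a number that can be told apart from that of compound 4.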